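Swapping the Amino Group on the Shared Core

The source may report more compounds than this note shows. Statements on the series, on what has been measured and on what is new or still open speak of the compounds shown alone.

Compound 1 `CC(C)(C)c1cc(NC(=O)c2c(Cl)cc(NCc3ccncc3)cc2Cl)ccc1O` and compound 2 `CC(C)(C)c1cc(NC(=O)c2c(Cl)cc(NC3CCCC3)cc2Cl)ccc1O` share one core and differ only in the group on the aromatic nitrogen. In an assay on isolated protein for antagonist activity at Bile acid receptor (Homo sapiens), read by HTRF, with a stated time of 30 min (on this read-out lower numbers stand for stronger inhibition and higher numbers for weaker inhibition), compound 2 gives 5000 nM, the lower of the two numbers, though its gap to compound 1 at 9800 nM is within the scatter, as the step of a 2.0-fold lower number from compound 1 to compound 2 (0.29 log units; within the scatter) shows. Compound 3 `CN(c1cc(Cl)c(C(=O)Nc2ccc(O)c(C(C)(C)C)c2)c(Cl)c1)C1CCCCC1` carries cyclohexyl(methyl)amino in place of cyclopentylamino on an aromatic carbon. Among the measured compounds shown here, the only measured step changed the same position and moved nothing beyond the scatter, so no shift beyond the scatter is expected here. Compound 3 is estimated at 4500 nM, within a range from 1500 nM to 14000 nM. The step of a 1.1-fold lower number from compound 2 to compound 3 (0.05 log units; within the scatter) is thus expected to stay within the scatter.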

Compound 3, half-maximal inhibitory concentration: > 100000 nM
Compound 3: no number, only a limit; the forecaster's own chance of this, stated with the estimate: 10%; at least 22-fold (1.34 log units) between middle value and limit.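

The earlier pair suggested that this position tolerates change, but this result shows that it does not tolerate every change: cyclohexyl(methyl)amino gives an at least 20-fold higher number from compound 2 to compound 3 (1.30 log units; beyond the scatter), and it gives an at least 10-fold higher number from compound 1 to compound 3 (1.00 log units; beyond the scatter). The reading for compound 3 is a limit, not a number: the limit of > 100000 nM in this assay, at which 1 of the 3 values shown sits. Compared with cyclopentylamino, the entering group has a six-membered ring instead of a five-membered one and 0 hydrogen-bond donors instead of 1.

The compounds shown leave open whether the ring or the methyl on the nitrogen accounts for the step. Cyclohexylamino, which has the larger ring but no methyl, would separate the two.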